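A few compounds are considered here, and "the series" means these few. Any claim that something is new, unique, unknown or untested is made for them only; others in the source may bear on it.

Measured so far:
compound 1 `COc1ccc(CNc2nc3cc(N)cc(N)c3nc2-c2ccccc2)cc1OC`, 30200 nM
compound 2 `COc1ccc(Sc2nc3cc(N)cc(N)c3nc2-c2ccccc2)cc1`, < 100000 nM

In a functional assay on SK-MEL-2 cells (Homo sapiens) for inhibition, read by sulforhodamine B assay, with a stated time of 48 h (on this read-out higher numbers stand for weaker inhibition of growth and lower numbers for stronger inhibition of growth), compound 1 gives 30200 nM. For compound 2 the read-out is a limit rather than a number: compound 2 gives < 100000 nM, and (the limit of < 100000 nM in this assay, at which 1 of the 2 values shown sits). So compound 2 stands at a limit in this assay, and no step between compound 1 and compound 2 can be sized from the two values.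

Compound 3 `Nc1cc(N)c2nc(-c3ccccc3)c(Sc3ccc(F)cc3)nc2c1` differs from compound 2 in one place: fluoro in place of methoxy on an aromatic carbon. No step of this kind has been measured among the compounds shown, so there is no precedent for its size. Fluoro in place of methoxy on an aromatic carbon is expected to move this assay by little, if anything, beyond the usual scatter, in either direction. The step is expected to come out as a step that the limit leaves unreadable from compound 2 to compound 3. Compound 3 is estimated at 40000 nM, in the range 10000 nM to 100000 nM.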

Compound 3, concentration for total growth inhibition: < 100000 nM
Compound 3: a limit, no number (the forecaster's own chance of this, stated with the estimate: 35%); the middle value lies beyond the limit too.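

Compound 3 gives < 100000 nM in this assay, which is a limit and not a number. No step between compound 2 and compound 3 can be read, because both sit at a limit: the limit of < 100000 nM in this assay, at which 2 of the 3 values shown sit.

The compounds shown leave open how far, and in which direction, fluoro in place of methoxy moves this read-out.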